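A few compounds are considered here, and "the series" means these few. Any claim that something is new, unique, unknown or untested is made for them only; others in the source may bear on it.

Notes on the series in an ADME assay on microsomes from liver (Mus musculus) for metabolic stability; a lower number here means slower removal, a higher number faster removal of the compound. Compound 1 (`O=C(Nc1ccc(Cl)cc1)C(=O)N1CCC(c2ccnc3ccc(F)cc23)CC1`) gives 97 mL.min-1.g-1, compound 2 (`O=C(Nc1ccc(Cl)cc1F)C(=O)N1CCC(c2ccnc3ccc(F)cc23)CC1`) gives 108 mL.min-1.g-1, and compound 3 (`O=C(Nc1ccc(C(F)(F)F)cc1)C(=O)N1CCC(c2ccnc3ccc(F)cc23)CC1`) gives 16 mL.min-1.g-1, the lowest of the three numbers.

Compound 4 (`O=C(Nc1ccc(C(F)F)cc1)C(=O)N1CCC(c2ccnc3ccc(F)cc23)CC1`) departs from compound 3 at one place: hydrogen in place of fluoro on a saturated chain carbon bound to an aromatic carbon and two fluorine atoms. This is hydrogen in place of fluoro on a saturated chain carbon bound to an aromatic carbon and two fluorine atoms, or trifluoromethyl to difluoromethyl.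

For the measured compounds named here, no measured step makes this exact change. The closest evidence is the entry of trifluoromethyl, seen in a 6.1-fold lower number from compound 1 to compound 3 (0.78 log units; beyond the scatter) and in a 6.8-fold lower number from compound 2 to compound 3 (0.83 log units; beyond the scatter), both modest and beyond the scatter. The change in a 1.1-fold higher number from compound 1 to compound 2 (0.05 log units; within the scatter) is on an aromatic carbon and gives little guidance here.

A rise in this assay is expected, a little beyond the scatter and smaller than those two steps. The expected step is a 2.2-fold higher number from compound 3 to compound 4 (0.34 log units; beyond the scatter). For compound 4 the estimated value is 35 mL.min-1.g-1, with an estimated range from 15 mL.min-1.g-1 to 85 mL.min-1.g-1.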

Compound 4, intrinsic clearance in microsomes: 76 mL.min-1.g-1
Estimate against measurement, compound 4: 2.2-fold (0.34 log units) below; low and high end bracket the measured number.
By their numbers in this assay, from the lowest: compound 3; then compounds 4, 1 and 2 (each within the scatter of the next).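

In this assay, hydrogen in place of one fluoro on the trifluoromethyl carbon gives a large rise (a 4.8-fold higher number from compound 3 to compound 4 (0.68 log units; beyond the scatter)), so the low number of compound 3 does not carry over to the closely related difluoromethyl group. Difluoromethyl reads the same as chloro within the scatter (a 1.3-fold lower number from compound 1 to compound 4 (0.11 log units; within the scatter)), and the exchange of 4-chloro-2-fluorophenyl for 4-(difluoromethyl)phenyl does likewise (a 1.4-fold lower number from compound 2 to compound 4 (0.15 log units; within the scatter)), leaving trifluoromethyl as the only group shown at this place that stands apart. Nothing available here accounts for this step.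

Whether the number keeps rising as fluorine is lost stays open, since monofluoromethyl and plain methyl do not figure among these compounds. Also open, as far as these compounds go, is how a methoxy group, a nitrile or an amine would read in place of trifluoromethyl.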